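Swapping Methoxy for Chloro: What Happens to Cytotoxicity?

The source may report more compounds than this note shows. Statements on the series, on what has been measured and on what is new or still open speak of the compounds shown alone.

Compound 1 `O=C(/C=C/c1cccc(Br)c1)c1cccc(-c2cccc(F)c2)c1`: 6980 nM
Compound 2 `COc1ccc(/C=C/C(=O)c2cccc(-c3cccc(F)c3)c2)cc1`: 1720 nM

Both compounds were tested in a functional assay on HepG2 cells (Homo sapiens) for cytotoxicity, read by sulforhodamine B assay, with a stated time of 48 h; a lower number here means a stronger inhibitor, a higher number a weaker inhibitor. Compound 2 has the lower of the two numbers, which makes it the stronger inhibitor so far. The next compound, compound 3 `O=C(/C=C/c1ccc(Cl)cc1)c1cccc(-c2cccc(F)c2)c1`, keeps the shared core and changes one group: chloro in place of methoxy on an aromatic carbon. Chloro takes the place of methoxy on an aromatic carbon, para to a large group, so 4-methoxyphenyl becomes 4-chlorophenyl.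

Among the compounds with values here, only one measured step bears on this: a 4.1-fold lower number from compound 1 to compound 2 (0.61 log units; beyond the scatter). There, 4-methoxyphenyl replaced 3-bromophenyl. A single step is a loose guide, and bromo and chloro are different groups. Compound 3 gives up the 4-methoxyphenyl, so a partial return towards compound 1 at 6980 nM is expected. The expected change is a 2.0-fold higher number from compound 2 to compound 3 (0.31 log units; beyond the scatter), a modest rise. Compound 3 is estimated at 3500 nM, with an expected range of 1300 nM to 9000 nM.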

Compound 3, half-maximal inhibitory concentration: 10400 nM
Compound 3: the middle estimate sits 3.0-fold (0.47 log units) below what was measured; measured number outside the range, above it.
By their numbers in this assay, from the lowest: compound 2; then compounds 1 and 3 (each within the scatter of the next).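

In this assay, the change from 4-methoxyphenyl to 4-chlorophenyl gives a 6.0-fold higher number from compound 2 to compound 3 (0.78 log units; beyond the scatter) and so removes the advantage that compound 2 held over compound 1. Compared with the 3-bromophenyl group, the 4-chlorophenyl group gives a 1.5-fold higher number from compound 1 to compound 3 (0.17 log units; within the scatter) and this lies within the scatter, so these two halogen-bearing compounds cannot be told apart here. Among these three compounds, only the one with methoxy stands apart, and no supporting data explain why.

Going by these compounds, it remains open whether a hydroxy, an ethoxy or a dimethylamino group in the same place would keep the lower number of compound 2. It is also unclear how much the ring place matters apart from the group itself, as the bromo of compound 1 sits in a different place from the chloro of compound 3.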